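A pyrazole for an alkyne chain, at a limit

This account rests on a few compounds, and the source may have more. Where it says the series, first, only, none or still open, it means among the compounds named here.

In an ADME assay (liver) for metabolic stability, with Liver microsome (Homo sapiens) as the target, using microsomes and NADPH, with a stated time of 30 min, tested at 1 uM (a higher number here means faster removal of the compound, a lower number slower removal), compound 1 `COc1cc(C(O)(C(F)(F)F)C(F)(F)F)cnc1N1CCN(S(=O)(=O)c2ccc(N)nc2)CC1` returns only a limit, < 14 mL.min-1.g-1. Compound 2 `Nc1ccc(S(=O)(=O)N2CCN(c3ncc(C(O)(C(F)(F)F)C(F)(F)F)cc3C#CCCO)CC2)cn1` also returns only a limit, < 14 mL.min-1.g-1.

Compound 3 `Cn1cc(-c2cc(C(O)(C(F)(F)F)C(F)(F)F)cnc2N2CCN(S(=O)(=O)c3ccc(N)nc3)CC2)cn1` differs from compound 2 in one place: 1-methyl-1H-pyrazol-4-yl in place of 4-hydroxybut-1-yn-1-yl on an aromatic carbon. Here 1-methyl-1H-pyrazol-4-yl stands in place of 4-hydroxybut-1-yn-1-yl on an aromatic carbon, ortho to a large group.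

Within the data shown here, the only measured step at this place is a step that the two limits leave unreadable from compound 1 to compound 2, with 4-hydroxybut-1-yn-1-yl in place of methoxy, and it offers no size to carry over. The evidence amounts to the limit of < 14 mL.min-1.g-1 in this assay, at which 2 of the 2 values shown sit. Both compounds sit at the limit, which is a thin basis for any pattern.

No step beyond the scatter is therefore expected in this assay, and the data argue for no direction. The expected change is a number no lower from compound 2 to compound 3 (the limit leaves the size open). For compound 3 the estimate is 14 mL.min-1.g-1, with an expected range from 9 mL.min-1.g-1 to 28 mL.min-1.g-1. Another report as a limit is expected to be the likeliest outcome.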

Compound 3, intrinsic clearance in microsomes: 19 mL.min-1.g-1
For compound 3 the middle estimate is 1.4-fold (0.13 log units) below the measured one, within the range that was stated.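

In this assay compound 3 gives 19 mL.min-1.g-1, the only value at this position among the compounds shown that is a number and not a limit. Putting 1-methyl-1H-pyrazol-4-yl on this aromatic carbon in place of 4-hydroxybut-1-yn-1-yl gives an at least 1.3-fold higher number from compound 2 to compound 3 (0.13 log units; that floor lies within the scatter), and putting it there in place of methoxy gives an at least 1.3-fold higher number from compound 1 to compound 3 (0.13 log units; that floor lies within the scatter), so each step has a floor but no full size, and neither is shown to go beyond the scatter. The position is thus no longer described by limits alone, although they still make up most of what is known about it: the limit of < 14 mL.min-1.g-1 in this assay, at which 2 of the 3 values shown sit.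

The compounds shown leave open how far the true values of compound 1 and compound 2 lie from their shared limit, and with that the full size of both steps. They also leave open whether an amine, a nitrile or a longer chain ending in a hydroxyl group at this position would return a number or another limit in this assay.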